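A few compounds are considered here, and "the series" means these few. Any claim that something is new, unique, unknown or untested is made for them only; others in the source may bear on it.

Working notes on the series. Compound 1 `CC(=O)OC/C1=C/C[C@](C)(CCC=C(C)C)/C=C/[C@@H](OC(=O)C=C(C)C)[C@](C)(OC(C)=O)/C=C/C1=O` and compound 2 `COC/C1=C/C[C@](C)(CCC=C(C)C)/C=C/[C@@H](OC(=O)C=C(C)C)[C@](C)(O)/C=C/C1=O` are the two members with a number in a functional assay on SW480 cells (Homo sapiens) for antiproliferative activity, read by MTT assay, with a stated time of 48 h; on this read-out higher numbers stand for weaker inhibition and lower numbers for stronger inhibition: compound 1 gives 3520 nM and compound 2 gives 3850 nM. Compound 3 `CC(C)=CCC[C@]1(C)/C=C/[C@@H](OC(=O)C=C(C)C)[C@](C)(O)/C=C/C(=O)/C(C(=O)O)=C\C1` returns only a limit in this assay, namely > 10000 nM. For the measured compounds named here, that puts compound 3 at the weak end of what has been measured, as the single value of the three sitting at the limit (the limit of > 10000 nM in this assay, at which 1 of the 3 values shown sits). Going by the values given here, the one measured step that reaches compound 3 is an at least 2.5-fold higher number from compound 2 to compound 3 (0.41 log units; beyond the scatter), carboxy in place of methoxymethyl on a double-bonded ring carbon.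

Compound 4 `CC(C)=CCC[C@]1(C)/C=C/[C@@H](OC(=O)C=C(C)C)[C@](C)(O)/C=C/C(=O)/C(CN=[N+]=[N-])=C\C1` differs from compound 3 by azidomethyl in place of carboxy on a double-bonded ring carbon. The carboxy, the group that came in with the loss seen in an at least 2.5-fold higher number from compound 2 to compound 3 (0.41 log units; beyond the scatter), leaves, and a group without a hydrogen-bond donor enters, so this change is read as a partial reversal of that step. A downward step is therefore expected in this assay, of a size comparable to the earlier loss, estimated as an at least 2.0-fold lower number from compound 3 to compound 4 (0.30 log units; that floor lies within the scatter). Compound 4 is accordingly expected at about 5000 nM, within 2500 nM to 12000 nM.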

Compound 4, half-maximal inhibitory concentration: 4230 nM
Compound 4: the middle estimate sits 1.2-fold (0.07 log units) above what was measured; low and high end bracket the measured number.
By their numbers in this assay, from the lowest: compounds 1, 2 and 4 (each within the scatter of the next). At a limit, above all of these: compound 3.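

In this assay, the loss seen at this double-bonded ring carbon is not shared by every group that replaces methoxymethyl: azidomethyl in place of carboxy gives an at least 2.3-fold lower number from compound 3 to compound 4 (0.37 log units; beyond the scatter). Azido in place of methoxy on the saturated chain carbon gives a 1.1-fold higher number from compound 2 to compound 4 (0.04 log units; within the scatter), so methoxymethyl and azidomethyl cannot be told apart here, and of the three groups compared at this carbon, only carboxy stands apart. Compound 3 remains a limit and not a number: the limit of > 10000 nM in this assay, at which 1 of the 4 values shown sits.

From the compounds shown here alone, whether an aminomethyl or a hydroxymethyl group at this carbon would stay level with compound 2 and compound 4 or fall towards compound 3 remains open. So does whether a methyl ester or a primary amide in place of the carboxy would behave like the carboxy or like azidomethyl.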